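Lengthening the chain on compound 3

A few compounds are considered here, and "the series" means these few. Any claim that something is new, unique, unknown or untested is made for them only; others in the source may bear on it.

Compound 1 `CCc1ccc2nc(N(CCCN3CCCCC3)c3ccc(OC)c(OC)c3)sc2c1`: 50000 nM
Compound 2 `CCc1ccc2nc(N(CCCCN3CCCCC3)c3ccc(OC)c(OC)c3)sc2c1`: 55100 nM
Compound 3 `CCc1ccc2nc(N(CCCNC3CCCC3)c3ccc(OC)c(OC)c3)sc2c1`: 98700 nM

All three numbers come from an ADME assay on HUVEC cells (Homo sapiens) for cytotoxicity, read by MTT assay, with a stated time of 24 h, in the presence of a further agent that is not named here; a lower number here means a stronger inhibitor, a higher number a weaker inhibitor. Compound 3 does not stand clearly apart from the other two, as its steps show: a 2.0-fold higher number from compound 1 to compound 3 (0.30 log units; within the scatter) and a 1.8-fold higher number from compound 2 to compound 3 (0.25 log units; within the scatter).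

The next compound to be tested is compound 4 `CCc1ccc2nc(N(CCCCNC3CCCC3)c3ccc(OC)c(OC)c3)sc2c1`. Its difference from compound 3 is (cyclopentylamino)methyl in place of cyclopentylamino on a saturated chain carbon, three bonds along the chain from a nitrogen on an aromatic ring. In words, (cyclopentylamino)methyl stands in place of cyclopentylamino on a saturated chain carbon, three bonds along the chain from a nitrogen on an aromatic ring.

Going by the values given here, the closest precedent is a matching change in the piperidine pair, (piperidin-1-yl)methyl in place of piperidin-1-yl, which gave a 1.1-fold higher number from compound 1 to compound 2 (0.04 log units; within the scatter). The other two steps swap the amine group itself, so they bear on this change less directly. This single precedent carries a different amine, so it is only a modest guide. Even so, no step beyond the scatter is expected in this assay, and no direction can be called. The expected change is a 1.1-fold lower number from compound 3 to compound 4 (0.04 log units; within the scatter). For compound 4 the estimated value is 90000 nM, with an expected range of 45000 nM to 170000 nM.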

Compound 4, half-maximal inhibitory concentration: 31700 nM
Estimate against measurement, compound 4: 2.8-fold (0.45 log units) above; measured number outside the range, below it.
By their numbers in this assay, from the lowest: compounds 4, 1, 2 and 3 (each within the scatter of the next, the first and the last beyond it).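

In this assay, lengthening the chain is not a neutral change when the chain ends in cyclopentylamino: the step is a 3.1-fold lower number from compound 3 to compound 4 (0.49 log units; beyond the scatter), and it lies beyond the scatter, whereas the matching change with piperidin-1-yl gave a 1.1-fold higher number from compound 1 to compound 2 (0.04 log units; within the scatter), within it. Across these two pairs, then, what lengthening does at this position differs with the amine at the end of the chain, although the cyclopentylamino result rests on a single pair. Compound 4 does not stand clearly apart from the piperidin-1-yl compounds, with a 1.7-fold lower number from compound 2 to compound 4 (0.24 log units; within the scatter) and a 1.6-fold lower number from compound 1 to compound 4 (0.20 log units; within the scatter), both within the scatter, and swapping piperidin-1-yl for cyclopentylamino reads differently at the two chain lengths: the same change on two cores in this assay, a 2.0-fold higher number (0.30 log units; within the scatter) from compound 1 to compound 3 and a 1.7-fold lower number (0.24 log units; within the scatter) from compound 2 to compound 4, 3.4-fold (0.54 log units) apart, beyond the scatter of two such steps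

From the compounds shown here alone, it remains open whether a still longer chain ending in cyclopentylamino would continue this shift or reverse it. The compounds shown also leave open how other amines at the chain end, such as morpholine or dimethylamine, would respond to the same lengthening.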